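Ether to Direct Aryl: Compound 2 Toward Compound 4

The source may hold more compounds than are shown below. What is called first, only, known or untested is meant among the compounds shown, and "the series" means these compounds.

Three compounds sharing one core were measured in an assay on CHO cells for antagonist activity at transient receptor potential cation channel subfamily V member 1 (Homo sapiens), read by FLIPR; a lower number here means a stronger inhibitor, a higher number a weaker inhibitor. Compound 1 `COc1ccc(N2CCN(c3cc(C(F)(F)F)ccc3CNC(=O)C(C)c3ccc(NS(C)(=O)=O)c(F)c3)CC2)cc1` gives 1.6 nM, compound 2 `CC(C(=O)NCc1ccc(C(F)(F)F)cc1OCc1ccc(F)cc1)c1ccc(NS(C)(=O)=O)c(F)c1` gives 0.5 nM, and compound 3 `C[C@@H](C(=O)NCc1ccc(C(F)(F)F)cc1SC1CCCCC1)c1ccc(NS(C)(=O)=O)c(F)c1` gives 13.9 nM. Compound 2 holds the lowest number of the three, and its gaps to compound 1 and to compound 3 both lie beyond the usual scatter, so it stands as the strongest inhibitor here. Compound 4 `CC(C(=O)NCc1ccc(C(F)(F)F)cc1-c1ccc(C(C)(C)C)cc1)c1ccc(NS(C)(=O)=O)c(F)c1` is not yet measured. It differs from compound 2 in one place: 4-(tert-butyl)phenyl in place of (4-fluorobenzyl)oxy on an aromatic carbon. Going by the values given here, no step between measured compounds isolates such a change, so the expectation rests on the three values alone. The expected step is a 5.0-fold higher number from compound 2 to compound 4 (0.70 log units; beyond the scatter), a modest weakening at most. Compound 4 is estimated at 2.5 nM, within 0.6 nM to 10 nM.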

Compound 4, inhibition constant: 1.1 nM
Beside the measured number, compound 4's estimate is 2.3-fold (0.36 log units) above it, within the range that was stated.
By their numbers in this assay, from the lowest: compound 2; then compounds 4 and 1 (each within the scatter of the next); then compound 3.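

At this aromatic carbon, meta to a trifluoromethyl group, 4-(tert-butyl)phenyl stands in for (4-fluorobenzyl)oxy at a modest cost in this assay, with a 2.2-fold higher number from compound 2 to compound 4 (0.34 log units; beyond the scatter). Strong inhibition therefore does not depend on a hydrogen-bond acceptor in the group at this position, since the all-carbon group has none. Nothing given here explains the size of this step. The compounds shown leave open how a carboxylic acid in place of the tert-butyl group would read here. A directly attached pyridine ring is equally untested among them.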